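Thiophene for phenyl in a thiocarbamate cytotoxicity series

The source may hold more compounds than are shown below. What is called first, only, known or untested is meant among the compounds shown, and "the series" means these compounds.

Compound 1 `S=C(Nc1ccccc1)OCCc1ccccn1`: > 100000 nM
Compound 2 `S=C(Nc1ccccc1)OCCc1ccccc1`: 100000 nM
Compound 3 `S=C(Nc1ccc(Cl)cc1)OCCc1ccccc1`: > 100000 nM

Going by the values given here, in an ADME assay on MT4 cells (Homo sapiens) for cytotoxicity, read by MTT assay (a lower number here means that less compound is tolerated, a higher number that more compound is tolerated), compound 2 gives 100000 nM, the only plain number among the three compounds measured. Compound 1 gives > 100000 nM, which is a limit of this assay. Compound 3 likewise gives > 100000 nM, again a limit. Compound 4 `S=C(Nc1ccccc1)OCCc1cccs1` differs from compound 2 by thiophen-2-yl in place of phenyl on a saturated chain carbon, two bonds along the chain from an oxygen on an unsaturated carbon. The step that bears on this exchange of an aryl group at the same chain position is a number no higher from compound 1 to compound 2 (the limit leaves the size open); the step of a number no lower from compound 2 to compound 3 (the limit leaves the size open) concerns a different place. Both steps rest on (the limit of > 100000 nM in this assay, at which 2 of the 3 values shown sit), so no size can be read from them. Compound 4 is therefore expected to stay within the scatter of compound 2, an expected step of no change at the digits printed from compound 2 to compound 4 (within the scatter). For compound 4 the estimate is 100000 nM, with a range from 45000 nM to 220000 nM.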

Compound 4, half-maximal cytotoxic concentration: > 100000 nM
Compound 4: only a limit was reported; the forecaster's own chance of this, stated with the estimate: 55%; the middle value sits exactly at the limit.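

In this assay compound 4 gives > 100000 nM, which is a limit. Thiophen-2-yl in place of phenyl gives a number no lower from compound 2 to compound 4 (the limit leaves the size open). Going by these compounds alone, a five-membered aromatic ring with a sulfur atom at this place thus joins pyridin-2-yl in reaching the limit, and compound 2, with phenyl, remains the only plain number among the aryl groups tried here. The steps to compound 4 from compound 1 and from compound 2 cannot be read: the limit of > 100000 nM in this assay, at which 3 of the 4 values shown sit.

Going by these compounds, whether any group at this place gives a clearly lower number stays open. An amine on the thiophen-2-yl ring or a longer chain could test this.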